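The compounds below may be only part of what the source reports. "The series", "measured", "known", "first", "only" and "open" are said of these compounds alone.

In a physicochemical assay for solubility, read by spectrophotometry, using the shake flask method, with a stated time of 2 days, at pH 6.5 (a higher number here means a more soluble compound, a lower number a less soluble compound), compound 1 (`O=C(O)COc1ccc2nc(-c3cn(-c4ccc(O)cc4)nn3)ccc2c1`) reads 365 ug/mL and stands highest of the three measured compounds. Compound 2 (`O=C(O)COc1ccc2nc(-c3cn(-c4ccc(O)c(F)c4)nn3)ccc2c1`) sits lower (37 ug/mL) and compound 3 (`COCCOc1cccc(Oc2cccc3nc(-c4cn(-c5ccc(O)c(F)c5)nn4)ccc23)c1`) lower still (6.1 ug/mL).

Compound 4 (`OCCOc1ccc2nc(-c3cn(-c4ccc(O)cc4)nn3)ccc2c1`) keeps the core of compound 1 and alters only its side chain: hydroxymethyl in place of carboxy on a saturated chain carbon bound to an oxygen on an aromatic ring. In words, hydroxymethyl stands in place of carboxy on a saturated chain carbon bound to an oxygen on an aromatic ring, which turns carboxymethoxy into 2-hydroxyethoxy.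

For the measured compounds named here, no measured step makes this swap. Going by the values given here, the one measured step is a different edit, fluoro in place of hydrogen on an aromatic carbon, and it gave a 9.9-fold lower number from compound 1 to compound 2 (0.99 log units; beyond the scatter). So a single small edit has already moved this number beyond the scatter, although that step says nothing direct about the carboxy group. Compound 3 also has no carboxy group and reads 6.1 ug/mL, but it differs from compound 1 in other places too, so it is only a loose guide.

On this thin evidence a fall is expected, similar in size to the fluoro step or somewhat larger. The estimated change is a 15-fold lower number from compound 1 to compound 4 (1.16 log units; beyond the scatter) and it is expected to appear in this assay as a clear drop. For compound 4 the expected value is 25 ug/mL with a wide estimated range (6 ug/mL to 100 ug/mL).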

Compound 4, solubility: 2.6 ug/mL
Estimate against measurement, compound 4: 9.6-fold (0.98 log units) above; the measured number lies below the stated range.
By their numbers in this assay, from the lowest: compound 4; then compound 3; then compound 2; then compound 1.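

In this assay, the change at this position gives a 140-fold lower number from compound 1 to compound 4 (2.15 log units; beyond the scatter), the only step among these compounds that alters the side chain itself. The edit looks small on paper: carboxy leaves and hydroxymethyl enters on a saturated chain carbon bound to an oxygen on an aromatic ring, with the count of hydrogen-bond donors and acceptors unchanged, yet the step is large, which shows that this place on compound 1 strongly affects the reading in a way the earlier fluoro step, made elsewhere, could not reveal. Nothing measured here explains why the number falls so far.

The compounds shown leave open whether the fall follows the loss of carboxy as such or is particular to hydroxymethyl, a question that an amide, an ester, an amine or a longer chain ending in a carboxylic acid at the same place could help to settle. Also open, going by these compounds, is how the same swap would read on compound 2, which carries the fluoro group.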